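Nitrophenyl placement in a thiadiazole acrylamide series

A few compounds are considered here, and "the series" means these few. Any claim that something is new, unique, unknown or untested is made for them only; others in the source may bear on it.

Compound 1 `N#C/C(=C\c1ccccc1OS(=O)(=O)c1ccc([N+](=O)[O-])cc1)C(=O)Nc1nnc(Cc2ccccc2)s1`: 57%
Compound 2 `N#C/C(=C\c1ccccc1OS(=O)(=O)c1ccccc1[N+](=O)[O-])C(=O)Nc1nnc(Cc2ccccc2)s1`: 71%
Compound 3 `N#C/C(=C\c1ccccc1OS(=O)(=O)c1ccc([N+](=O)[O-])cc1)C(=O)Nc1nnc(Cc2ccc(F)cc2)s1`: 55%

All three compounds were tested in a functional assay on RS4-11 cells (Homo sapiens) for inhibition, read by CCK-8 assay, with a stated time of 48 h, tested at 20 uM; a lower number here means less inhibition of growth, a higher number more inhibition of growth at the concentration tested. Compound 1 and compound 2 share a core and differ by 2-nitrophenyl in place of 4-nitrophenyl on a sulfonyl sulfur; this change gave a number 14 percentage points higher from compound 1 to compound 2 (beyond the scatter). Compound 1 and compound 3 differ by fluoro in place of hydrogen on an aromatic carbon, and that change gave a number 2 percentage points lower from compound 1 to compound 3 (within the scatter), so the two cores behave alike in this assay as far as these two numbers show.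

Compound 4 `N#C/C(=C\c1ccccc1OS(=O)(=O)c1ccccc1[N+](=O)[O-])C(=O)Nc1nnc(Cc2ccc(F)cc2)s1` has not yet been measured. It stands to compound 3 as compound 2 stands to compound 1: the difference is 2-nitrophenyl in place of 4-nitrophenyl on a sulfonyl sulfur, at a place described in the same words for both pairs, so it is the same change. Among the compounds shown it occurs twice in all. Because the earlier instance gave a number 14 percentage points higher from compound 1 to compound 2 (beyond the scatter), a step of about the same size is expected from compound 3 to compound 4, namely a number 14 percentage points higher from compound 3 to compound 4 (beyond the scatter). On that basis compound 4 is estimated to give 69% in this assay, with a range from 58% to 80%.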

Compound 4, percent growth inhibition at one concentration: 61%
Compound 4: the middle estimate sits 8 percentage points above what was measured; measured number inside the range.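

In this assay, the switch from 4-nitrophenyl to 2-nitrophenyl on the sulfonyl sulfur gave a number 6 percentage points higher from compound 3 to compound 4 (within the scatter), yet this step cannot be told apart from the one on the other core: the same change on two cores in this assay, a number 14 percentage points higher (beyond the scatter) from compound 1 to compound 2 and a number 6 percentage points higher (within the scatter) from compound 3 to compound 4, 8 percentage points apart, within the scatter of two such steps. The fluoro change reads the same way, with a number 10 percentage points lower from compound 2 to compound 4 (within the scatter), and it too matches its earlier counterpart: the same change on two cores in this assay, a number 2 percentage points lower (within the scatter) from compound 1 to compound 3 and a number 10 percentage points lower (within the scatter) from compound 2 to compound 4, 8 percentage points apart, within the scatter of two such steps. Taken together, these pairs are compatible with each change carrying from one core to the other, but only the first nitrophenyl step lies beyond the scatter, so they do not show a gain from 2-nitrophenyl on the fluoro-bearing core or a fixed step size across cores.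

Going by these compounds, only 2-nitrophenyl and 4-nitrophenyl appear on the sulfonyl sulfur, and only hydrogen and fluoro vary on the aromatic carbon, so it stays open how an aminophenyl or a carboxyphenyl on the sulfur, or a chloro or methoxy on that carbon, would behave. Also open, on these data alone, is how these compounds compare at other concentrations or in other cells.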